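Swapping the Oxadiazole for a Tetrazole on the Sulfur

This account rests on a few compounds, and the source may have more. Where it says the series, first, only, none or still open, it means among the compounds named here.

Compound 1 `CCOC(=O)c1c(C)noc1OCC(=O)[C@H](CC(=O)O)NC(=O)[C@@H](NC(=O)COc1cccc2ccccc12)C(C)C` gives in a functional assay on Jurkat cells (Homo sapiens) for inhibition (on this read-out lower numbers stand for stronger inhibition and higher numbers for weaker inhibition), only a limit, > 200000 nM.
Compound 2 `CC(C)[C@H](NC(=O)COc1cccc2ccccc12)C(=O)N[C@@H](CC(=O)O)C(=O)CSc1ncc[nH]1` gives only a limit as well, > 200000 nM.
Compound 3 `CC(C)[C@H](NC(=O)COc1cccc2ccccc12)C(=O)N[C@@H](CC(=O)O)C(=O)CSc1nnc(-c2ccccc2)o1` gives a number, 150000 nM.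

Compound 3 is thus the only one of the three with a measured number; the other two sit at the limit (the limit of > 200000 nM in this assay, at which 2 of the 3 values shown sit). Compound 4 `CC(C)[C@H](NC(=O)COc1cccc2ccccc12)C(=O)N[C@@H](CC(=O)O)C(=O)CSc1nnnn1-c1ccccc1` differs from compound 3 by 1-phenyl-1H-tetrazol-5-yl in place of 5-phenyl-1,3,4-oxadiazol-2-yl on a sulfur. The closest measured step is the earlier exchange on the same sulfur, an at least 1.3-fold lower number from compound 2 to compound 3 (0.12 log units; that floor lies within the scatter), which stays inside the scatter; the step of an at least 1.3-fold lower number from compound 1 to compound 3 (0.12 log units; that floor lies within the scatter) is equally small. A change of the same kind is therefore expected to move little, if at all, in this assay, and the step from compound 3 to compound 4 is estimated at no change at the digits printed from compound 3 to compound 4 (within the scatter). Compound 4 is expected to give about 150000 nM, between 50000 nM and 500000 nM, with a fair chance that only a limit is recorded.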

Compound 4, half-maximal inhibitory concentration: 153000 nM
Compound 4: middle estimate off by 1.0-fold (0.01 log units), on the low side; low and high end bracket the measured number.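

The 1-phenyl-1H-tetrazol-5-yl group on the sulfur gives the same picture as the 5-phenyl-1,3,4-oxadiazol-2-yl group in this assay (a 1.0-fold higher number from compound 3 to compound 4 (0.01 log units; within the scatter)), so two different phenyl-bearing rings now give measured numbers at this position. Set against the other two groups, compound 4 gives only floors (an at least 1.3-fold lower number from compound 2 to compound 4 (0.11 log units; that floor lies within the scatter)) and (an at least 1.3-fold lower number from compound 1 to compound 4 (0.11 log units; that floor lies within the scatter)), and both lie within the scatter, since compounds 1 and 2 are recorded only as limits: the limit of > 200000 nM in this assay, at which 2 of the 4 values shown sit.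

Still open, as far as these compounds go, is whether a chlorine atom or a methoxy group on the phenyl ring would move the number at all.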